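The source may report more compounds than this note shows. Statements on the series, on what has been measured and on what is new or still open speak of the compounds shown alone.

Compound 1 `CC(C)(C)c1ccc(NC(=O)Nc2cccc(CNc3ncnc4ccccc34)c2)cc1` and compound 2 `O=C(Nc1cccc(CNc2ncnc3ccccc23)c1)Nc1ccccc1F` share one core and differ in a single group: 2-fluorophenyl in place of 4-(tert-butyl)phenyl on an amide-type nitrogen. In a functional assay on HepG2 cells (Homo sapiens) for antiproliferative activity, read by MTT assay (a lower number here means a stronger inhibitor, a higher number a weaker inhibitor), compound 1 gives 17000 nM, and compound 2 gives 17500 nM, so the change made a 1.0-fold higher number from compound 1 to compound 2 (0.01 log units; within the scatter). Compound 3 `COc1cc2ncnc(NCc3cccc(NC(=O)Nc4ccc(C(C)(C)C)cc4)c3)c2cc1OC` has a different core; the difference between the two cores is not broken down here. In this assay compound 3 gives 6850 nM, the lowest of the three numbers, and its gaps to the other two lie beyond the scatter. Compound 4 `COc1cc2ncnc(NCc3cccc(NC(=O)Nc4ccccc4F)c3)c2cc1OC` has not yet been measured and differs from compound 3 by the same change: 2-fluorophenyl in place of 4-(tert-butyl)phenyl on an amide-type nitrogen. The surroundings of the change read the same in both pairs. The expected step is a 1.0-fold higher number from compound 3 to compound 4 (0.01 log units; within the scatter), because the matching change gave a 1.0-fold higher number from compound 1 to compound 2 (0.01 log units; within the scatter). In this assay compound 4 is expected to give 7000 nM, between 3500 nM and 14000 nM.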

Compound 4, half-maximal inhibitory concentration: 24900 nM
The estimate for compound 4 lay 3.6-fold (0.55 log units) below the measured number; measured number above the stated range.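

In this assay, putting 2-fluorophenyl in place of 4-(tert-butyl)phenyl gave a 3.6-fold higher number from compound 3 to compound 4 (0.56 log units; beyond the scatter), so the change did not carry over unchanged from one core to the other: the same change on two cores in this assay, a 1.0-fold higher number (0.01 log units; within the scatter) from compound 1 to compound 2 and a 3.6-fold higher number (0.56 log units; beyond the scatter) from compound 3 to compound 4, 3.5-fold (0.55 log units) apart, beyond the scatter of two such steps

The step seen on the core of compound 1 was therefore a poor guide to the step on the core of compound 3. With one pair on each core, this does not show why the two steps differ, or how the same change would behave on a further core.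

On these data alone, it remains open whether a plain phenyl or a cyclohexyl on the same nitrogen would also give different steps on these two cores. How the change would read on a core carrying a morpholine chain is open too.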